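The compounds below may be only part of what the source reports. "The series", "measured", "known", "first", "only" and "open" are said of these compounds alone.

Measured in a functional assay on DLD-1 cells (Homo sapiens) for antiproliferative activity, read by CellTiter-Glo, with a stated time of 72 h; on this read-out higher numbers stand for weaker inhibition and lower numbers for stronger inhibition:
- compound 1 `CC1CCN(C2CCN(S(=O)(=O)c3cn(C)cn3)CC2)CC1`: > 5000 nM (a limit of the assay, not a number)
- compound 2 `CC1CCN(C2CCN(S(=O)(=O)c3ccc(F)cc3F)CC2)CC1`: 102 nM

Going by the values given here, compound 2 holds the only true number so far, 102 nM. Compound 1 gives only a limit, (the limit of > 5000 nM in this assay, at which 1 of the 2 values shown sits).

The next compound is compound 3 `CC1CCN(C2CCN(S(=O)(=O)c3ccc(Cl)cc3Cl)CC2)CC1`, with 2,4-dichlorophenyl in place of 2,4-difluorophenyl on a sulfonyl sulfur. Among the compounds with values here, only one measured step bears on this change, and only indirectly. That step, an at least 49-fold lower number from compound 1 to compound 2 (1.69 log units; beyond the scatter), is large, but it exchanged 1-methyl-1H-imidazol-4-yl for 2,4-difluorophenyl at the same place. Within the data shown here, the present change keeps the six-membered aromatic ring of carbon only, and no measured step yet tests a swap of this kind. No step beyond the scatter is therefore expected in this assay, and no direction can be firmly assigned. The expected step is a 1.2-fold lower number from compound 2 to compound 3 (0.08 log units; within the scatter). For compound 3 the estimated value is 85 nM, with an expected range of 28 nM to 300 nM.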

Compound 3, half-maximal inhibitory concentration: 1 nM
For compound 3 the middle estimate is 85-fold (1.93 log units) above the measured one, outside the stated range (below it).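

On the sulfonyl sulfur, the kind of ring is not the only thing that counts in this assay: the six-membered aromatic ring of carbon only stays in place, yet 2,4-dichlorophenyl in place of 2,4-difluorophenyl gives a large change (a 100-fold lower number from compound 2 to compound 3 (2.01 log units; beyond the scatter)). The earlier comparison exchanged the whole ring, whereas this one shows that the halogens on a retained phenyl ring can by themselves shift the read-out well beyond the scatter, and the full exchange of 1-methyl-1H-imidazol-4-yl for 2,4-dichlorophenyl now spans more (an at least 5000-fold lower number from compound 1 to compound 3 (3.69 log units; beyond the scatter)). Going by these compounds, compound 1 gives > 5000 nM, which is a limit of the assay and not a number, so the true size of that wider step stays unknown: the limit of > 5000 nM in this assay, at which 1 of the 3 values shown sits.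

Open, on these data alone, is whether the step needs both chlorine atoms of the 2,4-dichlorophenyl group or whether one of them alone would carry most of it. Equally open, as far as these compounds go, is how a bromine, a methyl, a trifluoromethyl or an amine on the same phenyl ring would compare, and whether the chlorine gain persists with changes elsewhere on the shared core.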